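This account rests on a few compounds, and the source may have more. Where it says the series, first, only, none or still open, it means among the compounds named here.

Among the measured compounds shown here, compound 2 `O=C(NCc1ccc(Cl)cc1Cl)[C@@H]1CCC(=O)N1c1nccs1` gives 415 nM in an assay on HEK293 cells for inhibition of P2X purinoceptor 7 (Homo sapiens), read by flow cytometry, with stated times of 15 min and 1 h (a lower number here means a stronger inhibitor, a higher number a weaker inhibitor), the highest of the two numbers so far; compound 1 `O=C(NCc1ccc(Cl)cc1Cl)[C@@H]1CCC(=O)N1c1ccoc1` gives 200 nM, and a 2.1-fold higher number from compound 1 to compound 2 (0.32 log units; beyond the scatter). Compound 3 `O=C(NCc1ccc(Cl)cc1Cl)[C@@H]1CCC(=O)N1Cc1ccccc1Cl` carries 2-chlorobenzyl in place of 1,3-thiazol-2-yl on an amide-type nitrogen in a ring. For the measured compounds named here, no measured step covers this change: the only step in hand, from furan-3-yl to 1,3-thiazol-2-yl on the same nitrogen, was modest. The change to compound 3 is larger, replacing a five-membered aromatic ring with a 2-chlorobenzyl group, so some shift is expected, though its direction is not settled. Compound 3 is therefore expected near 500 nM, between 120 nM and 2000 nM. This amounts to an expected step of a 1.2-fold higher number from compound 2 to compound 3 (0.08 log units; within the scatter).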

Compound 3, half-maximal inhibitory concentration: 3460 nM
The estimate for compound 3 lay 6.9-fold (0.84 log units) below the measured number, and the stated range ends below it.
By their numbers in this assay, from the lowest: compound 1; then compound 2; then compound 3.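

Among the compounds shown here, on the amide-type nitrogen in a ring, the 2-chlorobenzyl group is the first replacement here with a six-membered aromatic ring of carbon only, and in this assay it gives an 8.3-fold higher number from compound 2 to compound 3 (0.92 log units; beyond the scatter) and a 17-fold higher number from compound 1 to compound 3 (1.24 log units; beyond the scatter) for the same change from the furan-3-yl compound. Activity at this nitrogen therefore varies much more with this change than with the exchange of the two five-membered aromatic rings. Nothing at hand accounts for the loss. The compounds shown leave open whether the chlorine or the benzyl group as a whole goes with the higher number. An unsubstituted benzyl or phenyl group on this nitrogen would separate the two.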